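Compound 4: methoxyphenyl in place of methylphenyl

The compounds below may be only part of what the source reports. "The series", "measured", "known", "first", "only" and "open" are said of these compounds alone.

Compound 1 `O=C(NC(=S)Nc1ccccc1Cl)Nc1ccc2c(c1)C(=O)C(=O)N2Cc1ccccc1` gives 3.01 in a physicochemical assay for lipophilicity, in phosphate buffer, measured as octanol-water partition (on this read-out lower numbers stand for lower lipophilicity and higher numbers for higher lipophilicity), compound 2 `Cc1cccc(NC(=S)NC(=O)Nc2ccc3c(c2)C(=O)C(=O)N3Cc2ccccc2)c1` gives 2.92, and compound 3 `Cc1ccc(NC(=S)NC(=O)Nc2ccc3c(c2)C(=O)C(=O)N3Cc2ccccc2)cc1` gives 2.96. Compound 3 stands second highest of the three numbers, yet within the scatter of both others: a number 0.05 log units lower from compound 1 to compound 3 (within the scatter) and a number 0.04 log units higher from compound 2 to compound 3 (within the scatter), as is a number 0.09 log units lower from compound 1 to compound 2 (within the scatter). Compound 4 `COc1cccc(NC(=S)NC(=O)Nc2ccc3c(c2)C(=O)C(=O)N3Cc2ccccc2)c1` carries 3-methoxyphenyl in place of 4-methylphenyl on an amide-type nitrogen. Going by the values given here, no measured step exchanges a methyl for a methoxy; the three known steps only swap chlorophenyl and methylphenyl groups and all stay within the scatter, so they give little guidance. The step of a number 0.41 log units lower from compound 3 to compound 4 (beyond the scatter) is an estimate, expected to lower the number in this assay beyond the scatter. For compound 4 the estimate is 2.55, with a range from 2.2 to 2.9.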

Compound 4, partition coefficient: 2.4
Estimate against measurement, compound 4: 0.15 log units above; the range from low to high includes it.
By their numbers in this assay, from the lowest: compound 4; then compounds 2, 3 and 1 (each within the scatter of the next).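

At the aryl group on the amide-type nitrogen, the chlorophenyl and methylphenyl swaps stayed within the scatter, whereas methoxy in place of methyl on an aromatic carbon gives a step beyond it in this assay: a number 0.52 log units lower from compound 2 to compound 4 (beyond the scatter). The other two steps to this compound, a number 0.56 log units lower from compound 3 to compound 4 (beyond the scatter) and a number 0.61 log units lower from compound 1 to compound 4 (beyond the scatter), are also beyond the scatter, so compound 4 stands apart from the other three. No available evidence bears on the origin of this separation.

On these data alone, whether an ethoxy group would follow methoxy remains open. So does the result with a hydroxy group or an amine on the same aromatic ring.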